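A Sulfur Swap Under a Solubility Limit

A few compounds are considered here, and "the series" means these few. Any claim that something is new, unique, unknown or untested is made for them only; others in the source may bear on it.

Three compounds with a shared core, compound 1 (`Cc1noc(-c2nc(C)c3c(c2N)C(=O)N(Cc2ccc(OC(F)(F)F)cc2)C3=O)n1`), compound 2 (`Cc1noc(-c2nc(C)c3c(c2N)C(=O)N(Cc2ccc(Br)cc2)C3=O)n1`) and compound 3 (`Cc1noc(-c2nc(C)c3c(c2N)C(=O)N(Cc2ccc(OC(F)F)cc2)C3=O)n1`), have been measured in a physicochemical assay for solubility, using the shake flask method, in simulated intestinal fluid, measured as kinetic solubility, with a stated time of 2 h, at 25 degrees C, at pH 6.5 (on this read-out lower numbers stand for lower solubility and higher numbers for higher solubility), so far. Compound 1 gives < 5000 nM as a limit and not a number. Compound 2 gives < 5000 nM as a limit as well. Going by these compounds, compound 3 stands at < 5000 nM as a limit too, so its true value is unknown, and the two further values beside it are also limits.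

Compound 4 (`Cc1noc(-c2nc(C)c3c(c2N)C(=O)N(Cc2ccc(SC(F)(F)F)cc2)C3=O)n1`) carries (trifluoromethyl)sulfanyl in place of difluoromethoxy on an aromatic carbon, para to a large group ((trifluoromethyl)sulfanyl in place of difluoromethoxy on an aromatic carbon). The nearest evidence is a step that the two limits leave unreadable from compound 1 to compound 2 when bromo replaces trifluoromethoxy, a step that the two limits leave unreadable from compound 1 to compound 3 when hydrogen replaces one fluoro, and a step that the two limits leave unreadable from compound 2 to compound 3 when difluoromethoxy replaces bromo. None of these steps has a readable size, so they give no direction for the new change. Another limit is the likeliest result in this assay because of the limit of < 5000 nM in this assay, at which 3 of the 3 values shown sit, across the whole set.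

The expected change is a step that the limit leaves unreadable from compound 3 to compound 4 and this is only a rough estimate. Compound 4 is estimated at 2500 nM with an expected range from 700 nM to 5000 nM when it is measured.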

Compound 4, solubility: < 5000 nM
Compound 4 ended at the assay's limit; the forecaster's own chance of this, stated with the estimate: 90%; the middle value lies beyond the limit too.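

In this assay compound 4 gives < 5000 nM, a limit and not a number. For the compounds shown here, no step to compound 4 from compound 1, compound 2 or compound 3 can be read, because all four compounds share the same limit: the limit of < 5000 nM in this assay, at which 4 of the 4 values shown sit. The compounds shown leave open how soluble each one truly is, and whether swapping the group on the aromatic carbon changes that at all.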